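This account rests on a few compounds, and the source may have more. Where it says the series, first, only, none or still open, it means among the compounds named here.

Working notes on the series.

In a functional assay on the whole organism for agonist activity, with Mus musculus as the target (a higher number here means that more compound is needed for the effect, a lower number that less compound is needed), compound 2 `CC(=O)N(C)CC#CCn1cncc1C` gives 45 mg/kg. Compound 1 `CC(=O)N(C)C(C)C#CCn1cncc1C` is the same core carrying one more carbon, and in this assay compound 1 gives only a limit, > 100 mg/kg, not a number. The change between them is methyl in place of hydrogen on a saturated chain carbon bound to an amide-type nitrogen and a triple-bonded carbon

The step of an at least 2.2-fold higher number from compound 2 to compound 1 (0.34 log units; beyond the scatter) is therefore known only as a lower bound, because compound 1 sits at the limit of > 100 mg/kg in this assay, at which 1 of the 3 values shown sits; the true size of the step may be larger than the bound given.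

Compound 3 `COC(=O)N(C)CC#CCN1CCCC1` has a different core; how its core differs from that of compound 2 is not broken down here. In this assay compound 3 gives 5.5 mg/kg, the lowest of the two numbers measured.

Compound 4 `COC(=O)N(C)C(C)C#CCN1CCCC1` is not yet measured. It differs from compound 3 by methyl in place of hydrogen on a saturated chain carbon bound to an amide-type nitrogen and a triple-bonded carbon

For the measured compounds named here, the two place lines read the same word for word, so the change from compound 3 to compound 4 is the same change as the one from compound 2 to compound 1, made on another core. Going by the values given here, the single measured instance gave an at least 2.2-fold higher number from compound 2 to compound 1 (0.34 log units; beyond the scatter), with only a lower bound on its size. On that basis the step of a 4.0-fold higher number from compound 3 to compound 4 (0.60 log units; beyond the scatter) is expected to be of at least the same order, with room for a larger rise since the measured instance is open-ended.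

Compound 4 is accordingly estimated at 22 mg/kg in this assay, with a range from 8 mg/kg to 70 mg/kg expected.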

Compound 4, dose for half-maximal effect: 14.2 mg/kg
Compound 4: the middle estimate sits 1.5-fold (0.19 log units) above what was measured; low and high end bracket the measured number.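

In this assay, methyl in place of hydrogen on a saturated chain carbon bound to an amide-type nitrogen and a triple-bonded carbon gives a 2.6-fold higher number from compound 3 to compound 4 (0.41 log units; beyond the scatter), a rise in the same direction as on the core of compound 2, and the two instances can be set side by side: the same change on two cores in this assay, an at least 2.2-fold higher number (0.34 log units; beyond the scatter) from compound 2 to compound 1 and a 2.6-fold higher number (0.41 log units; beyond the scatter) from compound 3 to compound 4; the limit leaves it open whether they differ

The direction of the change therefore carries over between these two cores, but a matching size is not shown, as the first instance rests on a limit for compound 1: the limit of > 100 mg/kg in this assay, at which 1 of the 4 values shown sits.

For the compounds shown here, with only two pairs, this says nothing about how the change behaves on any further core.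

The compounds shown leave open how ethyl or a longer chain on that same saturated chain carbon would read in this assay, and whether the rise continues with the size of the group there. Going by these compounds alone, they also leave open what each part of the core contributes on its own, as compound 2 and compound 3 differ in more than one place and no single-place pair connects the two cores.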